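Losing the sulfur-bearing group from compound 1

The compounds below may be only part of what the source reports. "The series", "measured", "known", "first", "only" and "open" are said of these compounds alone.

In a functional assay on KYSE-450 cells (Homo sapiens) for inhibition, read by CCK-8 assay, with a stated time of 48 h (a higher number here means a weaker inhibitor, a lower number a stronger inhibitor), compound 1 `CCN1CCN(C(=S)SCC(=O)N(Cc2ccc(OC)cc2)c2cc(OC)c(OC)c(OC)c2)CC1` gives 3070 nM and compound 3 `COc1ccc(CN(C(=O)CSC(=S)N2CCN(Cc3ccc(C(C)(C)C)cc3)CC2)c2cc(OC)c(OC)c(OC)c2)cc1` gives 2140 nM. These two values lie within the scatter of each other, with a 1.4-fold lower number from compound 1 to compound 3 (0.16 log units; within the scatter). Within the data shown here, compound 2 `COc1ccc(CN(C(=O)CSC(=S)N2CCN(C(=O)OC(C)(C)C)CC2)c2cc(OC)c(OC)c(OC)c2)cc1` gives 250 nM and is the one value clearly apart from the others, with a 12-fold lower number from compound 1 to compound 2 (1.09 log units; beyond the scatter), a large step, and an 8.6-fold higher number from compound 2 to compound 3 (0.93 log units; beyond the scatter), a modest one.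

Compound 4 `COc1ccc(CN(C(=O)CN2CCN(C(C)=O)CC2)c2cc(OC)c(OC)c(OC)c2)cc1` differs from compound 1 on a saturated chain carbon bound to a carbonyl carbon, where 4-acetylpiperazin-1-yl enters: a group of 9 heavy atoms (6 carbon, 2 nitrogen, 1 oxygen; one six-membered non-aromatic ring with 2 hetero atoms) in place of a group of 11 heavy atoms (7 carbon, 2 nitrogen, 2 sulfur; one six-membered non-aromatic ring with 2 hetero atoms), on a saturated chain carbon bound to a carbonyl carbon.

All the measured compounds keep the sulfur-bearing group, and their steps change only the substituent on an amine nitrogen in a ring. Among the measured compounds shown here, no measured step therefore tests the loss of that group, which could raise the number. For the measured compounds named here, compound 2, at 250 nM, carries tert-butoxycarbonyl on that nitrogen and is the nearest precedent for a carbonyl-bearing substituent there, which could lower the number. This rests on a single compound, and acetyl is a different group.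

With these two unknowns opposed, no step beyond the scatter is expected, the estimated step being a 1.3-fold higher number from compound 1 to compound 4 (0.11 log units; within the scatter). For compound 4 the expected value is 4000 nM, with an estimated range of 800 nM to 20000 nM.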

Compound 4, half-maximal inhibitory concentration: 10800 nM
Estimate against measurement, compound 4: 2.7-fold (0.43 log units) below; measured number inside the range.
By their numbers in this assay, from the lowest: compound 2; then compounds 3 and 1 (each within the scatter of the next); then compound 4.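

Among these compounds, compound 4 is the only compound here changed on the saturated chain carbon bound to a carbonyl carbon, and in this assay the change gives a 3.5-fold higher number from compound 1 to compound 4 (0.55 log units; beyond the scatter). Among the compounds shown here, this position therefore responds to change, whereas the earlier steps showed only the effect of the substituent on an amine nitrogen in a ring. Because the entering 4-acetylpiperazin-1-yl group removes both sulfur atoms and also puts acetyl where compound 1 has ethyl, this single step cannot assign the loss to either alteration, and nothing available bears on the reason for it.

Open, going by these compounds, is how much of the step belongs to the sulfur-bearing part and how much to the acetyl group, a question that 4-ethylpiperazin-1-yl in this same place would address directly. Also open, on these data alone, is whether a free amine on the ring nitrogen, or a longer chain carrying the ring on the saturated chain carbon, would keep the number near that of compound 1 or move it further.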